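Aryl replacement at the enone ring carbon of the core

The source may report more compounds than this note shows. Statements on the series, on what has been measured and on what is new or still open speak of the compounds shown alone.

Measured so far in an assay on CHO cells for displacement of a labelled ligand from Substance-P receptor (Homo sapiens), in the presence of a further agent that is not named here; a lower number here means a stronger inhibitor, a higher number a weaker inhibitor:
- compound 1 `C[C@@H](O[C@H]1CN2C(=O)C=C(c3ccc(NS(C)(=O)=O)cc3)CC2[C@@H]1c1ccc(F)cc1)c1cc(C(F)(F)F)cc(C(F)(F)F)c1`: 54 nM
- compound 2 `C[C@@H](O[C@H]1CN2C(=O)C=C(c3ccncc3)CC2[C@@H]1c1ccc(F)cc1)c1cc(C(F)(F)F)cc(C(F)(F)F)c1`: 8.1 nM

Compound 1 gives the highest number of the two; its nearest neighbour is compound 2, reached by a 6.7-fold lower number from compound 1 to compound 2 (0.82 log units; beyond the scatter), a step beyond the scatter.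

Compound 3 `COc1cc(C2=CC(=O)N3C[C@H](O[C@H](C)c4cc(C(F)(F)F)cc(C(F)(F)F)c4)[C@@H](c4ccc(F)cc4)C3C2)ccn1` is not yet measured. Its difference from compound 1 is 2-methoxypyridin-4-yl in place of 4-(methanesulfonamido)phenyl on a double-bonded ring carbon. Within the data shown here, the one measured step that bears on this change is the one from compound 1 to compound 2, where a pyridin-4-yl also took the place of the 4-(methanesulfonamido)phenyl and brought a 6.7-fold lower number from compound 1 to compound 2 (0.82 log units; beyond the scatter). Compound 3 carries the same pyridin-4-yl with a methoxy group added, so a step of roughly that size and in the same direction is expected in this assay, a 4.5-fold lower number from compound 1 to compound 3 (0.65 log units; beyond the scatter). For compound 3 the estimated value in this assay is 12 nM, with a range from 4 nM to 40 nM.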

Compound 3, half-maximal inhibitory concentration: 44 nM
Compound 3: middle estimate off by 3.7-fold (0.56 log units), on the low side; measured number outside the range, above it.
By their numbers in this assay, from the lowest: compound 2; then compounds 3 and 1 (each within the scatter of the next).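

In this assay the methoxy on an aromatic carbon of the pyridin-4-yl is far from a silent addition at this double-bonded ring carbon, giving a 5.4-fold higher number from compound 2 to compound 3 (0.73 log units; beyond the scatter) on the shared core. Against the 4-(methanesulfonamido)phenyl, the 2-methoxypyridin-4-yl gives a 1.2-fold lower number from compound 1 to compound 3 (0.09 log units; within the scatter) and so no separation between the two groups, which means the advantage of the pyridin-4-yl over that group does not persist once methoxy is present. No measured evidence here bears on the reason for this result.

As far as these compounds go, whether this step belongs to methoxy alone or to any group on that aromatic carbon remains open, and an amine or a methyl there would help to settle it. From the compounds shown here alone, how far the step depends on the shared core also remains open.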